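This account rests on a few compounds, and the source may have more. Where it says the series, first, only, none or still open, it means among the compounds named here.

Measured compounds in a functional assay on SH-SY5Y cells (Homo sapiens) for cytotoxicity, read by MTT assay, with stated times of 24 h and 4 h; a lower number here means that less compound is needed, a higher number that more compound is needed for the effect:

Compound 1 `COc1cc(CNC(=O)/C=C/c2ccccc2O)ccc1O`: 9760 nM
Compound 2 `COc1cc(CNC(=O)/C=C/c2ccccc2OCc2nc(C)c(C)nc2C)ccc1O`: 12000 nM
Compound 3 `COc1cc(CNC(=O)/C=C/c2ccc(OC)c(OC)c2OC)ccc1O`: 7450 nM

The three measured compounds share the same amide-linked left-hand portion and differ on the right-hand aromatic ring. Compound 2 is compound 1 with one change, ((3,5,6-trimethylpyrazin-2-yl)methyl in place of hydrogen on an oxygen on an aromatic ring). In this assay this change gave a 1.2-fold higher number from compound 1 to compound 2 (0.09 log units; within the scatter), so the two compounds are not separated by the assay. Compound 3 differs from compound 1 in more than one place on the right-hand ring, and the difference between the two cores is not broken down here; the values of compound 1 and compound 3 lie within the usual scatter of each other, as do those of compound 2 and compound 3.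

Compound 4 `COc1cc(CNC(=O)/C=C/c2ccc(OC)c(OC)c2OC)ccc1OCc1nc(C)c(C)nc1C` has not yet been measured. It stands to compound 3 as compound 2 stands to compound 1: the change is (3,5,6-trimethylpyrazin-2-yl)methyl in place of hydrogen on an oxygen on an aromatic ring, and the place of the change is described in the same words for both pairs, so it is the same change made on a different core. Among the measured compounds shown here, the one earlier instance of this change left the number essentially where it was. On that basis compound 4 is expected to give an estimated 9000 nM in this assay, with an expected range of 4000 nM to 20000 nM. For the measured compounds named here, this means an expected step of a 1.2-fold higher number from compound 3 to compound 4 (0.08 log units; within the scatter) from compound 3 to compound 4, resting on the single earlier step of a 1.2-fold higher number from compound 1 to compound 2 (0.09 log units; within the scatter) and on the value of compound 3, 7450 nM. Going by the values given here, with only one prior example of the change, the expected range is kept wide.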

Compound 4, half-maximal effective concentration: 3840 nM
Estimate against measurement, compound 4: 2.3-fold (0.37 log units) above; the whole stated range lies above it.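

In this assay, placing (3,5,6-trimethylpyrazin-2-yl)methyl in place of hydrogen on an oxygen on an aromatic ring of the core of compound 3 gave a 1.9-fold lower number from compound 3 to compound 4 (0.29 log units; within the scatter), so this assay does not separate the two compounds. Set beside the earlier instance of the same change, this step does not differ from it by more than the assay can resolve: the same change on two cores in this assay, a 1.2-fold higher number (0.09 log units; within the scatter) from compound 1 to compound 2 and a 1.9-fold lower number (0.29 log units; within the scatter) from compound 3 to compound 4, 2.4-fold (0.38 log units) apart, within the scatter of two such steps The two pairs therefore show that, on these two cores, the change leaves the read-out within the usual scatter, but with only two pairs and neither step resolved, they do not show that the change has a real effect in either direction or that its effect depends on the core.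

The oxygen carries only hydrogen or (3,5,6-trimethylpyrazin-2-yl)methyl in the compounds shown, which leaves open how a plain methyl, a longer alkyl chain or a chain ending in an amine would read in this assay. Also open, on these data alone, is whether the same change would behave alike on a core whose right-hand ring carries a carboxylic acid or a fluorine, and whether the pattern would hold in any other assay.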